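Thiazolyloxy replacing pyrimidinyl on the shared core

This account rests on a few compounds, and the source may have more. Where it says the series, first, only, none or still open, it means among the compounds named here.

Measured so far in a functional assay on CHO cells for positive allosteric modulation of muscarinic acetylcholine receptor M5 (Homo sapiens), read by FLIPR and calcium flux, with a stated time of 1 h; on this read-out higher numbers stand for an effect only at larger amounts of compound and lower numbers for an effect already at smaller amounts:
compound 1 `COc1cccc(Oc2ccc(CN3C(=O)C(=O)c4cc(OC(F)(F)F)ccc43)cc2)n1` gives 2200 nM
compound 2 `O=C1C(=O)N(Cc2ccc(-c3cncnc3)cc2)c2ccc(OC(F)(F)F)cc21` gives 2100 nM

For the measured compounds named here, compound 2 stands at the lowest of the two numbers so far, though its nearest neighbour, compound 1, lies within the scatter of it: a 1.0-fold lower number from compound 1 to compound 2 (0.02 log units; within the scatter). The two compounds therefore cannot be told apart on this read-out.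

Compound 3 `O=C1C(=O)N(Cc2ccc(Oc3nccs3)cc2)c2ccc(OC(F)(F)F)cc21` has not yet been measured. It differs from compound 2 in one place: (1,3-thiazol-2-yl)oxy in place of pyrimidin-5-yl on an aromatic carbon. Going by the values given here, the only measured step that bears on this kind of change is the one from compound 1 to compound 2, where an aryloxy group gave way to a directly attached six-membered heteroaryl ring with no change beyond the scatter. Compound 3 carries an aryloxy group again, more like compound 1 than compound 2 in that respect, and both measured compounds sit at nearly the same number. No step beyond the scatter is therefore expected in this assay for compound 3, which is estimated at 2100 nM with a range from 800 nM to 5500 nM. This estimate means a step of no change at the digits printed from compound 2 to compound 3 (within the scatter) is expected.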

Compound 3, half-maximal effective concentration: 2800 nM
Compound 3: the middle estimate sits 1.3-fold (0.12 log units) below what was measured; the range from low to high includes it.
By their numbers in this assay, from the lowest: compounds 2, 1 and 3 (each within the scatter of the next).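

In this assay, the aromatic carbon para to a large group now carries a five-membered aromatic ring attached through oxygen, and the exchange for the directly attached pyrimidin-5-yl amounts to a 1.3-fold higher number from compound 2 to compound 3 (0.12 log units; within the scatter). With the oxygen kept in place, exchanging only the ring on it gives a 1.3-fold higher number from compound 1 to compound 3 (0.10 log units; within the scatter), so a five-membered and a six-membered aromatic ring on that oxygen cannot be told apart on this read-out. Taken together, the three compounds show that neither the ring size, the attachment through oxygen nor the methoxy group on the pyridine separates them here, and nothing available explains why these exchanges leave the numbers so close. From the compounds shown here alone, whether any group at this position can move the number beyond the scatter stays open, since all three compounds carry an aromatic ring there, and an amine, a carboxylic acid or a longer alkoxy chain in its place would test this. The trifluoromethoxy group also stays the same throughout, so the effect of a chlorine atom or a methyl group in its place on the shared core is open as well.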